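The compounds below may be only part of what the source reports. "The series", "measured", "known", "first", "only" and "open" are said of these compounds alone.

Compound 1, `CC1(C)CC(=O)C(C(=S)SCc2ccccc2)=C(Nc2ccc(Cl)cc2Cl)C1`, in a functional assay on PBMC cells (Homo sapiens) for inhibition, read by ELISA, with a stated time of 18 h (a lower number here means a stronger inhibitor, a higher number a weaker inhibitor), gives > 20 ug/mL, which is a limit of the assay. Compound 2, `CCCCSC(=S)C1=C(Nc2ccc(Cl)cc2)CC(C)(C)CC1=O`, in this assay gives > 20 ug/mL, again only a limit. Compound 3, `CCCCCCCCCCCSC(=S)C1=C(Nc2ccc(Cl)cc2)CC(C)(C)CC1=O`, in this assay gives > 20 ug/mL, also a limit.

Compound 3 thus stands at a limit, as do the other two, all three sitting at the limit of > 20 ug/mL in this assay, at which 3 of the 3 values shown sit. The step from compound 2 to compound 3 is a step that the two limits leave unreadable from compound 2 to compound 3. Compound 4, `CC1(C)CC(=O)C(C(=S)SCc2ccccc2)=C(Nc2ccc(Cl)cc2)C1`, differs from compound 3 by phenyl in place of decyl on a saturated chain carbon bound to a sulfur. Among the compounds with values here, no measured step reads on this change; every value in the set is a limit, so only a limit can be carried forward. The step meant by the estimate, a step that the limit leaves unreadable from compound 3 to compound 4, is expected to be none beyond the scatter. Compound 4 is expected to give 30 ug/mL, with a range from 10 ug/mL to 80 ug/mL.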

Compound 4, half-maximal inhibitory concentration: > 20 ug/mL
Compound 4: no number, only a limit; the forecaster's own chance of this, stated with the estimate: 75%; the middle value is on the limit's open side.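

Compound 4 gives > 20 ug/mL in this assay, which is a limit, so its steps from compound 1, compound 2 and compound 3 cannot be read. The compounds shown leave open whether any of these changes alters inhibition.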